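This account rests on a few compounds, and the source may have more. Where it says the series, first, only, none or still open, it means among the compounds named here.

Compound 1 `CSc1cnc2ccccc2c1SCC#CCOC(=O)/C=C/c1ccccc1`: 9.4 ug/mL
Compound 2 `CCOC(=O)OCC#CCSc1c(SC)cnc2ccccc12`: 5.5 ug/mL
Compound 3 `CSc1cnc2ccccc2c1SCC#CCO`: 49.8 ug/mL

In a functional assay on B16 cells (Mus musculus) for antiproliferative activity, with a stated time of 72 h (on this read-out lower numbers stand for stronger inhibition and higher numbers for weaker inhibition), compound 2 gives the lowest of the three numbers. The nearest step is a 1.7-fold lower number from compound 1 to compound 2 (0.23 log units; within the scatter), which stays within the scatter; the furthest is a 9.1-fold higher number from compound 2 to compound 3 (0.96 log units; beyond the scatter). Compound 4 `CSc1cnc2ccccc2c1SCC#CCOC(=O)c1ccc(C(=O)O)cc1` has not yet been measured. It differs from compound 2 by 4-carboxyphenyl in place of ethoxy on a carbonyl carbon. The step from compound 1 to compound 2 bears on this, as it also exchanged the group on the carbonyl carbon, and it stayed within the scatter. The step from compound 2 to compound 3 removed the ethoxycarbonyl altogether, which compound 4 does not do. Within the data shown here, no measured compound carries a 4-carboxyphenyl group, so that part is untested. The number for compound 4 is therefore expected to stay close to compound 2, a step of a 1.5-fold higher number from compound 2 to compound 4 (0.16 log units; within the scatter). Compound 4 is estimated at 8 ug/mL, within a range from 3 ug/mL to 25 ug/mL.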

Compound 4, concentration for 50% inhibition: 18.1 ug/mL
For compound 4 the middle estimate is 2.3-fold (0.35 log units) below the measured one; the measured number falls inside the stated range.
By their numbers in this assay, from the lowest: compounds 2, 1 and 4 (each within the scatter of the next, the first and the last beyond it); then compound 3.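

In this assay the exchange on the carbonyl carbon now gives a step beyond the scatter (a 3.3-fold higher number from compound 2 to compound 4 (0.52 log units; beyond the scatter)), so what sits at this position can matter, which the earlier exchange there did not show. Compared with 2-phenylethenyl, however, 4-carboxyphenyl cannot be told apart (a 1.9-fold higher number from compound 1 to compound 4 (0.28 log units; within the scatter)), as this step stays within the scatter. No supporting measurement accompanies these numbers to explain the step. Which part of 4-carboxyphenyl matters, the carboxylic acid or the six-membered aromatic ring, remains open. From the compounds shown here alone, how an amine or a longer chain would read on this carbonyl carbon also remains open.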